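Acylation of an Amine: Expected Cytotoxicity of Compound 3

The source may hold more compounds than are shown below. What is called first, only, known or untested is meant among the compounds shown, and "the series" means these compounds.

Compound 1 `CCCCCCCCCCCCCCC(NC(=O)OC(C)(C)C)C(=O)O` and compound 2 `CCCCCCCCCCCCCCC(N)COCc1ccccc1` were both tested in an ADME assay on cells (Splenocyte, Mus musculus, strain BALB/c) for cytotoxicity, read by MTT assay, tested at 10 ug/mL; a higher number here means a stronger effect of the compound at the concentration tested, a lower number a weaker effect. In this assay compound 1 gives 5.1%, and compound 2 gives 12.2%. Compound 2 stands highest of the two numbers, but its nearest neighbour, compound 1, lies within the scatter of it. Compound 3 `CCCCCCCCCCCCCCC(COCc1ccccc1)NC(=O)CCCC(=O)OC` differs from compound 2 by (3-(methoxycarbonyl)propyl)carbonyl in place of hydrogen on an amine nitrogen. Within the data shown here, no step between measured compounds is available, so the step from compound 2 to compound 3 is expected to stay within the scatter, in no clear direction. Compound 3 is estimated at 10%, with a range from 2% to 22%. This means an expected step of a number 2.2 percentage points lower from compound 2 to compound 3 (within the scatter).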

Compound 3, a percentage reported as activity, at one concentration (the size of the read-out at that concentration, not a potency): 2.5%
Compound 3: the middle estimate sits 7.5 percentage points above what was measured; measured number inside the range.
By their numbers in this assay, from the lowest: compounds 3, 1 and 2 (each within the scatter of the next).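

In this assay, among these compounds, the first step at this position is a number 9.7 percentage points lower from compound 2 to compound 3 (within the scatter), so the amine nitrogen of compound 2 can carry (3-(methoxycarbonyl)propyl)carbonyl without a step beyond the scatter. This rests on a single pair of compounds and shows nothing of a direction. No available measurement accounts for this step. The compounds shown leave open whether a carboxylic acid in place of the methyl ester at the chain end would behave the same way. They also leave open whether a shorter acyl group such as acetyl, or a longer acyl chain, on this nitrogen would stay within the scatter.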